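Fluoro in place of propylamino: expected shift in rat

This account rests on a few compounds, and the source may have more. Where it says the series, first, only, none or still open, it means among the compounds named here.

Within the data shown here, in a functional assay on the whole organism with Rattus norvegicus as the target (on this read-out lower numbers stand for an effect already at smaller amounts and higher numbers for an effect only at larger amounts of compound), compound 1 `CCCNc1cccc(NC(=O)C(=O)OCC)c1C#N` gives 0.7 mg/kg, the second highest of the three numbers measured so far. Compound 2 `CCOC(=O)C(=O)Nc1cccc(N(C)CC)c1C#N` gives 0.5 mg/kg, and the step of a 1.4-fold lower number from compound 1 to compound 2 (0.15 log units; within the scatter) lies within the scatter. Compound 3 `CCOC(=O)C(=O)Nc1cccc([N+](=O)[O-])c1C#N` gives 82 mg/kg; the step of a 120-fold higher number from compound 1 to compound 3 (2.07 log units; beyond the scatter) is large, as is the step of a 160-fold higher number from compound 2 to compound 3 (2.21 log units; beyond the scatter).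

Compound 4 `CCOC(=O)C(=O)Nc1cccc(F)c1C#N` has not yet been measured. It differs from compound 1 in one place: fluoro in place of propylamino on an aromatic carbon. Compounds 1 and 2, carrying propylamino and ethyl(methyl)amino, sit close together, while the only measured departure from such a group, to nitro in compound 3, comes with the large step of a 120-fold higher number from compound 1 to compound 3 (2.07 log units; beyond the scatter). Fluoro is neither an amino group nor nitro, so these two large steps bear on the change but do not fix its size. For compound 4 a higher number than for compound 1 is expected, though a smaller rise than that to compound 3. The estimate for compound 4 is 8 mg/kg, with a range from 2 mg/kg to 40 mg/kg. The expected step is therefore an 11-fold higher number from compound 1 to compound 4 (1.06 log units; beyond the scatter).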

Compound 4, dose for half-maximal effect: 59 mg/kg
Compound 4: the middle estimate sits 7.4-fold (0.87 log units) below what was measured, outside the stated range (above it).
By their numbers in this assay, from the lowest: compounds 2 and 1 (each within the scatter of the next); then compounds 4 and 3 (each within the scatter of the next).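

In this assay, fluoro in place of propylamino gives a large rise (an 84-fold higher number from compound 1 to compound 4 (1.93 log units; beyond the scatter)), and fluoro in place of ethyl(methyl)amino gives another (a 120-fold higher number from compound 2 to compound 4 (2.07 log units; beyond the scatter)). Fluoro and nitro stay within the scatter of each other (a 1.4-fold lower number from compound 3 to compound 4 (0.14 log units; within the scatter)), so the large rise is no longer tied to nitro alone: at this carbon, ortho to a cyano group, both groups without an amino nitrogen stand apart from both amino groups. Nothing available bears on what lies behind this split.

Whether the low numbers need a chain on the nitrogen remains open, as neither an unsubstituted amine nor a longer chain on that nitrogen appears among these compounds. Also open, from the compounds shown here alone, is whether a methoxy group, with oxygen in place of the nitrogen, would sit with the amino compounds or with fluoro and nitro.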